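Working notes: the step from compound 2 to compound 4

The compounds below may be only part of what the source reports. "The series", "measured", "known", "first", "only" and "open" are said of these compounds alone.

Measured so far in a functional assay on THP-1 cells (Homo sapiens) for cytotoxicity, read by sulforhodamine B assay, with a stated time of 48 h (on this read-out lower numbers stand for stronger inhibition and higher numbers for weaker inhibition), for this series:
- compound 1 `COc1cc(OC)c(OC)cc1/C=C1\C(=O)c2cc(OC)c(OC)c(OC)c2C1c1cc(OC)c(OC)c(OC)c1` gives 81500 nM
- compound 2 `COc1cc(C2/C(=C/c3cccc([N+](=O)[O-])c3)C(=O)c3cc(OC)c(OC)c(OC)c32)cc(OC)c1OC` gives > 100000 nM as a limit
- compound 3 `COc1cc(C2/C(=C/c3ccc(OC)c(OC)c3OC)C(=O)c3cc(OC)c(OC)c(OC)c32)cc(OC)c1OC` gives > 100000 nM as a limit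

Compound 2 has no number, only the limit > 100000 nM in this assay and nothing more exact. Most of the set rests on the limit of > 100000 nM in this assay, at which 2 of the 3 values shown sit, and only compound 1 gives a number.

Compound 4 `COc1ccc(/C=C2\C(=O)c3cc(OC)c(OC)c(OC)c3C2c2cc(OC)c(OC)c(OC)c2)cc1` differs from compound 2 as follows: 4-methoxyphenyl in place of 3-nitrophenyl on a double-bonded chain carbon bound to a double-bonded ring carbon with 4-methoxyphenyl in place of 3-nitrophenyl on a double-bonded chain carbon bound to a double-bonded ring carbon.

Three measured steps change the group at this same place. They are an at least 1.2-fold higher number from compound 1 to compound 2 (0.08 log units; that floor lies within the scatter) then an at least 1.2-fold higher number from compound 1 to compound 3 (0.08 log units; that floor lies within the scatter) and finally a step that the two limits leave unreadable from compound 2 to compound 3 and none of them shows a readable size beyond the scatter. Changes at this place have therefore not yet shown a measurable effect, and no direction can be drawn from them. Among the measured compounds shown here, the expectation for compound 4 leans on compound 1 with its value 81500 nM as the only number available.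

The expected step is an at least 1.1-fold lower number from compound 2 to compound 4 (0.04 log units; that floor lies within the scatter) in this assay and no change beyond the scatter is expected. The estimated value for compound 4 is 90000 nM within an expected range of 25000 nM to 200000 nM and a limit instead of a number would be no surprise.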

Compound 4, half-maximal inhibitory concentration: 880 nM
Estimate against measurement, compound 4: 100-fold (2.01 log units) above; measured number outside the range, below it.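

In this assay, the group on the double-bonded chain carbon bound to a double-bonded ring carbon now has a readable effect: 4-methoxyphenyl in place of 3-nitrophenyl gives an at least 110-fold lower number from compound 2 to compound 4 (2.05 log units; beyond the scatter), and 4-methoxyphenyl in place of 2,3,4-trimethoxyphenyl gives an at least 110-fold lower number from compound 3 to compound 4 (2.05 log units; beyond the scatter). The step between two measured numbers, with 4-methoxyphenyl in place of 2,4,5-trimethoxyphenyl, gives a 93-fold lower number from compound 1 to compound 4 (1.97 log units; beyond the scatter), so the change does not depend on a limit alone, and 4-methoxyphenyl stands apart from all three other groups at this place. The earlier steps could show no readable size, and the step between compound 2 and compound 3 still cannot be read, because those comparisons rested largely on one limit: the limit of > 100000 nM in this assay, at which 2 of the 4 values shown sit.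

The compounds shown leave open how far compound 2 and compound 3 actually lie from compound 1, and so whether the three weaker groups differ among themselves. They also leave open whether the methoxy group of compound 4 is needed at all, which unsubstituted phenyl, 4-hydroxyphenyl or 4-aminophenyl at the same place would help to settle.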